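The compounds below may be only part of what the source reports. "The series", "measured", "known", "first", "only" and "open" are said of these compounds alone.

Measured compounds:
compound 1, `Cc1cc(NC(=O)Cn2nnc(-c3ccccc3)n2)n(C2CCC(F)(F)CC2)n1`, 84 nM
compound 2, `Cc1cc(NC(=O)Cn2nnc(-c3cc(Cl)cc(Cl)c3)n2)n(C2CCCCC2)n1`, 980 nM

Both numbers come from an assay on HEK293 cells for activation of Kir3.1/Kir3.2 (Homo sapiens), read by thallium flux; on this read-out higher numbers stand for an effect only at larger amounts of compound and lower numbers for an effect already at smaller amounts. In this assay compound 1 gives 84 nM and compound 2 gives 980 nM. Compound 2 stands at the higher of the two numbers; its nearest neighbour is compound 1, whose number is the lower, and the gap between them is beyond the usual scatter. For the measured compounds named here, no single-point step between the two has been worked out, since compound 1 and compound 2 differ in more than one place, so the pair can only be read as two values side by side.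

Compound 3, `Cc1cc(NC(=O)Cn2nnc(-c3cccc(C(F)(F)F)c3)n2)n(C2CCCCC2)n1`, awaits measurement in this assay. It is derived from compound 2 by the change (3-(trifluoromethyl)phenyl in place of 3,5-dichlorophenyl on an aromatic carbon).

Going by the values given here, the measured pair offers no direct guide to a change at this position; the only hint is that compound 1, with a different ring at this place and a different group elsewhere, sits well below compound 2. A modest move toward lower numbers is expected, as a 2.0-fold lower number from compound 2 to compound 3 (0.29 log units; within the scatter), though not with confidence beyond the scatter. Compound 3 is estimated at 500 nM, with a likely range from 150 nM to 2000 nM.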

Compound 3, half-maximal effective concentration: 183 nM
Compound 3: the middle estimate sits 2.7-fold (0.44 log units) above what was measured; the measured number falls inside the stated range.
By their numbers in this assay, from the lowest: compound 1; then compound 3; then compound 2.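

In this assay, the aromatic carbon of the five-membered ring with 4 nitrogen now has its first single-point step: 3-(trifluoromethyl)phenyl in place of 3,5-dichlorophenyl gives a 5.4-fold lower number from compound 2 to compound 3 (0.73 log units; beyond the scatter) with the rest of the molecule unchanged. The position therefore responds to the substitution on the phenyl ring beyond the usual scatter, and 3,5-dichlorophenyl is not required for a number as low as that of compound 3. No measurement at hand separates the loss of the two chlorine atoms from the arrival of the trifluoromethyl group, and nothing available accounts for the step.

Going by these compounds, compound 1 differs from compound 3 in more than one place, so it remains open whether the step would carry over with the fluorinated ring of compound 1 in place of the cyclohexyl ring. On these data alone, it also remains open how this position would respond to a phenyl ring bearing a nitrile, an amine or a carboxylic acid, or to a pyridine ring in place of the phenyl ring.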